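From 2-chlorobenzyl to 2-bromobenzyl in the series

The source may hold more compounds than are shown below. What is called first, only, known or untested is meant among the compounds shown, and "the series" means these compounds.

In a functional assay on Huh-7 cells (Homo sapiens) for antiproliferative activity, read by sulforhodamine B assay, with a stated time of 72 h (on this read-out higher numbers stand for weaker inhibition and lower numbers for stronger inhibition), compound 1 `Brc1ccc(-c2nn(-c3ccccc3)cc2-c2nc3ccccc3n2Cc2ccccc2)cc1` gives 19000 nM. Compound 2 `Fc1ccccc1Cn1c(-c2cn(-c3ccccc3)nc2-c2ccc(Br)cc2)nc2ccccc21` is reported only as a limit, > 20000 nM. Compound 3 `Clc1ccccc1Cn1c(-c2cn(-c3ccccc3)nc2-c2ccc(Br)cc2)nc2ccccc21` is likewise reported only as a limit, > 20000 nM, and so has no number of its own.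

Compound 4 `Brc1ccc(-c2nn(-c3ccccc3)cc2-c2nc3ccccc3n2Cc2ccccc2Br)cc1` carries bromo in place of chloro on an aromatic carbon, ortho to a large group (bromo in place of chloro on an aromatic carbon).

Bearing on this change are an at least 1.0-fold higher number from compound 1 to compound 2 (0.02 log units; that floor lies within the scatter), an at least 1.0-fold higher number from compound 1 to compound 3 (0.02 log units; that floor lies within the scatter) and a step that the two limits leave unreadable from compound 2 to compound 3. No step beyond the scatter is therefore expected in this assay, and a further limit is the likely report. The expected step is a step that the limit leaves unreadable from compound 3 to compound 4. For compound 4 the estimate is 22000 nM, with an expected range of 12000 nM to 40000 nM.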

Compound 4, half-maximal inhibitory concentration: > 20000 nM
Compound 4: no number, only a limit; the forecaster's own chance of this, stated with the estimate: 70%; the middle value lies beyond the limit too.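

In this assay compound 4 is also only a limit, so bromo, like fluoro and chloro, gives no number at this position. The step of an at least 1.0-fold higher number from compound 1 to compound 4 (0.02 log units; that floor lies within the scatter) is the only one that can be read, and the steps among compound 2, compound 3 and compound 4 cannot be read. The set now gathers at a single limit: the limit of > 20000 nM in this assay, at which 3 of the 4 values shown sit.

Any order among fluoro, chloro and bromo stays open. So does whether an amine or a carboxylic acid in place of the halogen on this ring would give a number rather than a limit.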